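Working notes on a small cytotoxicity series

The source may hold more compounds than are shown below. What is called first, only, known or untested is meant among the compounds shown, and "the series" means these compounds.

Measured compounds, each giving only a limit of the assay in a functional assay on HepG2 cells (Homo sapiens) for cytotoxicity, read by MTT assay, with a stated time of 48 h; on this read-out lower numbers stand for stronger inhibition and higher numbers for weaker inhibition:
compound 1, `Cc1nnc(SCC(=O)c2ccc(Cl)cc2)n1N1C(=O)c2ccccc2C1=O`: > 200000 nM, a limit
compound 2, `C#CCSc1nnc(C)n1N1C(=O)c2ccccc2C1=O`: > 200000 nM, a limit
compound 3, `C#CCSc1nnc(-c2cc(OC)c(OC)c(OC)c2)n1N1C(=O)c2ccccc2C1=O`: > 200000 nM, a limit

Compound 1 differs from compound 2 by (4-chlorophenyl)carbonyl in place of ethynyl on a saturated chain carbon bound to a sulfur, and the step that the two limits leave unreadable from compound 2 to compound 1 cannot be read because of the limit of > 200000 nM in this assay, at which 3 of the 3 values shown sit. The difference between the cores of compound 2 and compound 3 is not broken down here.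

Compound 4, `COc1cc(-c2nnc(SCC(=O)c3ccc(Cl)cc3)n2N2C(=O)c3ccccc3C2=O)cc(OC)c1OC`, is not yet measured; it differs from compound 3 by (4-chlorophenyl)carbonyl in place of ethynyl on a saturated chain carbon bound to a sulfur, the same change as from compound 2 to compound 1. In this assay the step is expected to be a number no higher from compound 3 to compound 4 (the limit leaves the size open). This rests on compound 3, whose value > 200000 nM is a limit, and on the earlier unreadable step. Compound 4 is therefore expected at 200000 nM, most likely again only a limit, within 50000 nM to 400000 nM.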

Compound 4, half-maximal inhibitory concentration: 22000 nM
The estimate for compound 4 lay 9.1-fold (0.96 log units) above the measured number; measured number outside the range, below it.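

In this assay, (4-chlorophenyl)carbonyl in place of ethynyl on a saturated chain carbon bound to a sulfur gives an at least 9.0-fold lower number from compound 3 to compound 4 (0.95 log units; beyond the scatter), and 3,4,5-trimethoxyphenyl in place of methyl on an aromatic carbon gives an at least 9.0-fold lower number from compound 1 to compound 4 (0.95 log units; beyond the scatter). Both sizes are minimums, so the change is shown to matter on the core of compound 3, but how much it matters remains unknown. The same change on the core of compound 2 cannot be read, so carrying it from one core to another is not shown, because of where the values sit: the limit of > 200000 nM in this assay, at which 3 of the 4 values shown sit.

Only compound 4 carries both groups, and it leaves open whether either group alone could ever give a number on the core of compound 2. Also open, on these data alone, is whether an amine or a carboxylic acid in place of (4-chlorophenyl)carbonyl would keep a readable value.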